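The source may report more compounds than this note shows. Statements on the series, on what has been measured and on what is new or still open speak of the compounds shown alone.

Compound 1 `Cc1cc(Nc2cc(-c3ccccc3)[nH]n2)n2nc(SCc3ccc(F)cc3)nc2n1` is one of three measured compounds sharing a core and differing only on the benzyl group attached through sulfur. In a functional assay on MGC-803 cells (Homo sapiens) for inhibition, read by MTT assay, with a stated time of 72 h (on this read-out higher numbers stand for weaker inhibition and lower numbers for stronger inhibition), compound 1 gives 3270 nM, the second highest of the three numbers. Compound 3 `Cc1cc(Nc2cc(-c3ccccc3)[nH]n2)n2nc(SCc3ccc(C(F)(F)F)cc3)nc2n1` gives 3520 nM in this assay, and the step from compound 1 to compound 3 is a 1.1-fold higher number from compound 1 to compound 3 (0.03 log units; within the scatter), within the scatter. Compound 2 `Cc1cc(Nc2cc(-c3ccccc3)[nH]n2)n2nc(SCc3ccc(Br)cc3)nc2n1` gives 1110 nM, and the step from compound 1 to compound 2 is a 2.9-fold lower number from compound 1 to compound 2 (0.47 log units; beyond the scatter), a modest improvement.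

Compound 4 `CCCSc1nc2nc(C)cc(Nc3cc(-c4ccccc4)[nH]n3)n2n1` is not yet measured. It differs from compound 1 by ethyl in place of 4-fluorophenyl on a saturated chain carbon bound to a sulfur. Among the measured compounds shown here, none of the measured steps bears directly on this change: each of them exchanges one group on the aromatic ring for another, whereas here the ring itself is removed. Those steps show only that alterations at this end of the molecule move the number by modest amounts, as in a 3.2-fold higher number from compound 2 to compound 3 (0.50 log units; beyond the scatter). With the ring gone entirely, compound 4 is expected to give a weaker result, a step of a 2.1-fold higher number from compound 1 to compound 4 (0.33 log units; beyond the scatter), so compound 4 is estimated at 7000 nM, with a range from 2000 nM to 25000 nM.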

Compound 4, half-maximal inhibitory concentration: 12600 nM
Estimate against measurement, compound 4: 1.8-fold (0.26 log units) below, within the range that was stated.
By their numbers in this assay, from the lowest: compound 2; then compounds 1 and 3 (each within the scatter of the next); then compound 4.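

Removing the aromatic ring altogether, a change that the earlier exchanges on that ring could not test, weakens the result in every comparison: this assay records a 3.9-fold higher number from compound 1 to compound 4 (0.59 log units; beyond the scatter) and a 3.6-fold higher number from compound 3 to compound 4 (0.55 log units; beyond the scatter) and, against the bromo compound, an 11-fold higher number from compound 2 to compound 4 (1.06 log units; beyond the scatter). That last step is the only large one in the series, and compound 4 is the weakest of the four, so an aromatic ring at this end of the molecule goes with the stronger results here, whichever of fluoro, bromo or trifluoromethyl it carries. Nothing available gives a reason for this loss.

On these data alone, it remains open how a plain benzyl group, with no substituent on the ring, would compare, and whether a longer chain such as hexyl would stand nearer compound 4 or compound 1. Also open, as far as these compounds go, is whether an amine or a carboxylic acid at the end of the propyl chain would move the number in either direction.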